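The source may report more compounds than this note shows. Statements on the series, on what has been measured and on what is new or still open speak of the compounds shown alone.

In a functional assay on QG-56 cells (Homo sapiens) for antiproliferative activity (on this read-out higher numbers stand for weaker inhibition and lower numbers for stronger inhibition), compound 1 `Cn1cncc1[C@@](N)(c1ccc(C#N)cc1)c1cc2cc(C#N)cc(-c3cccc(F)c3)c2o1` gives 2 nM and compound 2 `Cn1cncc1C(O)(c1ccc(Cl)cc1)c1cc2cc([N+](=O)[O-])cc(-c3ccccc3)c2o1` gives 1890 nM which is the higher of the two numbers. Compound 2 therefore stands as the weaker inhibitor of this pair, by a margin well beyond the usual scatter. Compound 3 `Cn1cncc1C(O)(c1ccc(C(=O)O)cc1)c1cc2cc([N+](=O)[O-])cc(-c3ccccc3)c2o1` has not been measured yet. It differs from compound 2 in one place carboxy in place of chloro on an aromatic carbon with carboxy in place of chloro on an aromatic carbon, para to a large group. For the measured compounds named here, no measured pair shows this change, so the forecast has little to rest on. A moderate step towards a higher number, meaning weaker inhibition, is expected in this assay and is estimated as a 2.6-fold higher number from compound 2 to compound 3 (0.42 log units; beyond the scatter) with real doubt about its size. Compound 3 is estimated at 5000 nM with an expected range from 1200 nM to 20000 nM as a rough guess.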

Compound 3, half-maximal inhibitory concentration: > 10000 nM
Compound 3 ended at the assay's limit (the forecaster's own chance of this, stated with the estimate: 15%); middle value at least 2.0-fold (0.30 log units) from the limit.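

Putting carboxy in place of chloro at this position, para to a large group, gives an at least 5.2-fold higher number from compound 2 to compound 3 (0.72 log units; beyond the scatter) in this assay. For the compounds shown here, this is the first direct view of a single change at this place, and it shows that the 4-carboxyphenyl compound inhibits clearly less well than its 4-chlorophenyl partner. The step gives only a minimum size, because compound 3 reached a limit of the assay rather than a true number, so the full loss cannot be read: the limit of > 10000 nM in this assay, at which 1 of the 3 values shown sits.

The compounds shown leave open whether another group at this place, such as an amine, a methyl ester or a longer chain ending in a carboxylic acid, would keep more of the inhibition. They also leave open whether the same change would have a similar effect on the core of compound 1.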